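Chloro in Place of Hydrogen, Repeated on a Second Core

The source may hold more compounds than are shown below. What is called first, only, known or untested is meant among the compounds shown, and "the series" means these compounds.

Three compounds have been measured in a functional assay on MGC-803 cells (Homo sapiens) for antiproliferative activity, read by MTT assay, with a stated time of 72 h; a higher number here means a weaker inhibitor, a lower number a stronger inhibitor:
compound 1 `O=C(COc1ccc(C(=O)/C=C/c2ccc(Cl)cc2Cl)cc1)N[C@H]1CCOC1=O` gives 26500 nM;
compound 2 `O=C(COc1ccc(C(=O)/C=C/c2ccccc2Cl)cc1)N[C@H]1CCOC1=O` gives 27100 nM;
compound 3 `O=C(CNc1ccccc1)N[C@H]1CCOC1=O` gives > 64000 nM, which is a limit of the assay and not a number.

Compound 1 and compound 2 share one core and differ in a single place: chloro in place of hydrogen on an aromatic carbon. The step is a 1.0-fold lower number from compound 2 to compound 1 (0.01 log units; within the scatter), so the two values cannot be told apart. Compound 3 is built on a different core; how the two cores differ is not broken down here. For compound 3 the assay reports only a limit, (the limit of > 64000 nM in this assay, at which 1 of the 3 values shown sits), and no number stands behind it.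

Compound 4 `O=C(CNc1ccccc1Cl)N[C@H]1CCOC1=O` has not yet been measured. It differs from compound 3 in the same way that compound 1 differs from compound 2: chloro in place of hydrogen on an aromatic carbon. The surroundings of the place are not identical, though. In compound 1 the chlorine enters meta to a chloro group and para to a large group, whereas in compound 4 it enters ortho to a large group, so this is the same kind of change rather than the same change.

On the strength of a 1.0-fold lower number from compound 2 to compound 1 (0.01 log units; within the scatter) a step that the limit leaves unreadable from compound 3 to compound 4 is expected from compound 3 to compound 4. Compound 4 is therefore estimated at 70000 nM, expected to fall between 30000 nM and 150000 nM. Since compound 3 itself gave only a limit, compound 4 is expected quite possibly to give only a limit as well.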

Compound 4, half-maximal inhibitory concentration: > 64000 nM
Compound 4 was reported as a limit; the forecaster's own chance of this, stated with the estimate: 75%; the middle value is on the limit's open side.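

In this assay compound 4 gives > 64000 nM, which is a limit of the assay and not a number. Within the data shown here, compound 3 also stands at a limit, so no step between compound 3 and compound 4 can be read: the limit of > 64000 nM in this assay, at which 2 of the 4 values shown sit. The compounds shown leave open whether chloro in place of hydrogen on an aromatic carbon changes the number at all on the core of compound 3.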